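The source may report more compounds than this note shows. Statements on the series, on what has been measured and on what is new or still open speak of the compounds shown alone.

Compound 3 `CO[C@@]12CCN(C)C[C@H]1[C@H](c1ccc3ccccc3c1)C(C#N)=C(N)O2` is one of three compounds with a shared core that have so far been tested in a functional assay on trachea (Cavia porcellus) (a lower number here means a stronger inhibitor, a higher number a weaker inhibitor), and in that assay compound 3 gives 24200 nM. Beside it stand compound 1 `CCN1CC[C@@]2(OC)OC(N)=C(C#N)[C@@H](c3ccccc3)[C@@H]2C1`, which in this assay gives 23400 nM, and compound 2 `CCCN1CC[C@@]2(OC)OC(N)=C(C#N)[C@@H](c3ccccc3)[C@@H]2C1`, which gives 20700 nM. The values of compound 1 and compound 3 lie within the scatter of each other, as do those of compound 2 and compound 3, so compound 3 cannot be placed apart from either.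

The compound that follows is compound 4 `CCCN1CC[C@@]2(OC)OC(N)=C(C#N)[C@@H](c3ccc4ccccc4c3)[C@@H]2C1`, which differs from compound 3 by ethyl in place of hydrogen on a saturated chain carbon bound to an amine nitrogen in a ring. For the measured compounds named here, the one measured step that bears on this change is the lengthening of the same chain on the ring nitrogen: a 1.1-fold lower number from compound 1 to compound 2 (0.05 log units; within the scatter). Going by the values given here, that step, cut one bond further out from the nitrogen, is the same kind of change as the one from compound 3 to compound 4, and it left the number essentially unmoved.

On that basis the step of a 1.2-fold lower number from compound 3 to compound 4 (0.06 log units; within the scatter) is expected to stay within the scatter. For compound 4 the estimate in this assay is therefore 21000 nM, with a range from 10000 nM to 42000 nM.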

Compound 4, half-maximal inhibitory concentration: 37100 nM
Estimate against measurement, compound 4: 1.8-fold (0.25 log units) below, within the range that was stated.
By their numbers in this assay, from the lowest: compounds 2, 1, 3 and 4 (each within the scatter of the next).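

Ethyl in place of hydrogen on a saturated chain carbon bound to an amine nitrogen in a ring, the difference that reads methyl to propyl, now has a reading of its own in this assay: the result is a 1.5-fold higher number from compound 3 to compound 4 (0.19 log units; within the scatter) and it adds a second pair to the earlier one, which showed a 1.1-fold lower number from compound 1 to compound 2 (0.05 log units; within the scatter) on the same chain. Both steps stay within the scatter even though the two pairs carry different groups elsewhere on the shared core, so in neither pair does the number in this assay respond measurably to a change of chain at this position. No evidence on hand speaks to why this is so.

On these data alone, what remains open is whether a longer chain such as butyl, or a chain ending in an amine or a carboxylic acid, would carry the number beyond the scatter at this position. It is equally open whether a benzyl group in place of propyl on this nitrogen would separate from the compounds shown.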